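Swapping a branched amine chain for an aminocyclohexyl ring

This account rests on a few compounds, and the source may have more. Where it says the series, first, only, none or still open, it means among the compounds named here.

Compound 1 `CC(C)C[C@@H](N)C(=O)Nc1cc2cc[nH]c(=O)c2cc1Cl`: 19 nM
Compound 2 `CC(C)(C)C[C@@H](N)C(=O)Nc1cc2cc[nH]c(=O)c2cc1Cl`: 110 nM

Among the measured compounds shown here, in an assay on isolated protein for inhibition of Rho-associated protein kinase 2 (Homo sapiens) (on this read-out higher numbers stand for weaker inhibition and lower numbers for stronger inhibition), compound 2 gives 110 nM, the highest of the two numbers measured so far. For the measured compounds named here, its only neighbour is compound 1, which in this assay gives 19 nM; the single measured step, a 5.8-fold higher number from compound 1 to compound 2 (0.76 log units; beyond the scatter), shows that adding a methyl on the branched chain carbon weakens inhibition by a modest but real margin.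

Compound 3 `N[C@H]1CC[C@@H](C(=O)Nc2cc3cc[nH]c(=O)c3cc2Cl)CC1` differs from compound 2 by 4-aminocyclohexyl in place of 1-amino-3,3-dimethylbutyl on a carbonyl carbon. Going by the values given here, no measured step covers a change of this kind: the one known step concerns a methyl added to an open chain, not the closing of the amine-bearing chain into a ring, so it bears on the new step only indirectly, by showing that the amine-bearing side group tolerates change within a modest range. The same shared core and the same chlorine are kept.

On that footing the expected movement is a 3.7-fold lower number from compound 2 to compound 3 (0.56 log units; beyond the scatter), with the number for compound 3 estimated at 30 nM, in the range 8 nM to 120 nM.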

Compound 3, half-maximal inhibitory concentration: 15 nM
Beside the measured number, compound 3's estimate is 2.0-fold (0.30 log units) above it, and the stated range covers the measured number.
By their numbers in this assay, from the lowest: compounds 3 and 1 (each within the scatter of the next); then compound 2.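

In this assay, putting 4-aminocyclohexyl on the carbonyl carbon in place of 1-amino-3,3-dimethylbutyl gives a 7.3-fold lower number from compound 2 to compound 3 (0.87 log units; beyond the scatter), so this position accepts a six-membered carbon ring as well as an open chain, and the weaker inhibition of compound 2 does not extend to every change of the group at this position. Set against the 1-amino-3-methylbutyl chain, the same ring gives a 1.3-fold lower number from compound 1 to compound 3 (0.10 log units; within the scatter), so the ring and that chain cannot be told apart on this read-out. No measurement shown here offers an explanation for either step.

The compounds shown leave open whether the amine on the ring matters at all, which a plain cyclohexyl or a 4-hydroxycyclohexyl group at the same place would address. They also leave open how the other stereoisomer of 4-aminocyclohexyl, or a smaller ring such as aminocyclopentyl, would compare with compound 3 in this assay.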